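Isobutyl in Place of Hydrogen: Expected Cell Toxicity

The compounds below may be only part of what the source reports. "The series", "measured", "known", "first", "only" and "open" are said of these compounds alone.

Measured compounds:
compound 1 `CN1C(=O)C(C2=NS(=O)(=O)c3cc(NS(C)(=O)=O)ccc3N2)=C(O)C2CCCC21`: "not determined" (no result reported)
compound 2 `CS(=O)(=O)Nc1ccc2c(c1)S(=O)(=O)N=C(C1=C(O)[C@H]3CCCC[C@H]3N(Cc3ccc(F)cc3)C1=O)N2`: > 1000 nM

In an ADME assay on Huh-7 cells (Homo sapiens) for cytotoxicity, with a stated time of 72 h (on this read-out higher numbers stand for lower toxicity in this test and lower numbers for higher toxicity in this test), compound 1 has no reported result. In this assay compound 2 gives > 1000 nM, which is a limit of the measurement rather than a number, and it sits at the limit of > 1000 nM in this assay, at which 1 of the 2 values shown sits. Compound 3 `CC(C)CCN1C(=O)C(C2=NS(=O)(=O)c3cc(NS(C)(=O)=O)ccc3N2)=C(O)C2CCCC21` shares the core of compound 1 and differs from it by isobutyl in place of hydrogen on a saturated chain carbon bound to an amide-type nitrogen in a ring. Among the measured compounds shown here, no measured step is available to set a size or direction for this change, so no shift beyond the usual scatter is assumed. Compound 3 is expected to give 20000 nM in this assay, with a likely range from 3000 nM to 100000 nM.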

Compound 3, half-maximal cytotoxic concentration: > 1000 nM
Compound 3: a limit, no number (the forecaster's own chance of this, stated with the estimate: 75%); the middle value is on the limit's open side.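

Among the compounds shown here, no step from compound 1 to compound 3 can be read: compound 1 has no reported result, and compound 3 gives only a limit. Left open is whether isobutyl in place of hydrogen changes cell toxicity at all, and by how much.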